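Swapping the Sulfonyl Aryl Group in a Growth-Inhibition Series

This account rests on a few compounds, and the source may have more. Where it says the series, first, only, none or still open, it means among the compounds named here.

Compound 1 `N#C/C(=C\c1ccccc1OS(=O)(=O)c1ccccc1[N+](=O)[O-])C(=O)Nc1nnc(Cc2ccccc2)s1` and compound 2 `N#C/C(=C\c1ccccc1OS(=O)(=O)c1ccc(Cl)cc1)C(=O)Nc1nnc(Cc2ccccc2)s1` share one core; compound 2 differs from compound 1 by 4-chlorophenyl in place of 2-nitrophenyl on a sulfonyl sulfur. In a functional assay on RS4-11 cells (Homo sapiens) for inhibition, read by CCK-8 assay, with a stated time of 48 h, tested at 20 uM (on this read-out higher numbers stand for more inhibition of growth at the one concentration tested and lower numbers for less inhibition of growth), compound 1 gives 71%, and compound 2 gives 73%, so that a number 2 percentage points higher from compound 1 to compound 2 (within the scatter). Compound 3 `N#C/C(=C\c1ccccc1OS(=O)(=O)c1ccccc1[N+](=O)[O-])C(=O)Nc1nnc(Cc2ccc(Cl)cc2)s1` differs from compound 1 by chloro in place of hydrogen on an aromatic carbon; in this assay compound 3 gives 65%, a step of a number 6 percentage points lower from compound 1 to compound 3 (within the scatter). Compound 4 `N#C/C(=C\c1ccccc1OS(=O)(=O)c1ccc(Cl)cc1)C(=O)Nc1nnc(Cc2ccc(Cl)cc2)s1` has not yet been measured. It differs from compound 3 by 4-chlorophenyl in place of 2-nitrophenyl on a sulfonyl sulfur, the same change, at the same place, that separates compound 1 from compound 2. Because that earlier change gave a number 2 percentage points higher from compound 1 to compound 2 (within the scatter), for compound 4 the expected step is a number 2 percentage points higher from compound 3 to compound 4 (within the scatter) in this assay, resting on that single measured pair alone. Compound 4 is therefore estimated at 67%, with a range from 55% to 79%.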

Compound 4, percent growth inhibition at one concentration: 64%
For compound 4 the middle estimate is 3 percentage points above the measured one; low and high end bracket the measured number.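

In this assay, 4-chlorophenyl in place of 2-nitrophenyl on a sulfonyl sulfur gave, on a second core, a number 1 percentage points lower from compound 3 to compound 4 (within the scatter), and the two cores agree on this change: the same change on two cores in this assay, a number 2 percentage points higher (within the scatter) from compound 1 to compound 2 and a number 1 percentage points lower (within the scatter) from compound 3 to compound 4, 3 percentage points apart, within the scatter of two such steps. Chloro in place of hydrogen on an aromatic carbon gave a number 9 percentage points lower from compound 2 to compound 4 (within the scatter), and this change also agrees across two cores: the same change on two cores in this assay, a number 6 percentage points lower (within the scatter) from compound 1 to compound 3 and a number 9 percentage points lower (within the scatter) from compound 2 to compound 4, 3 percentage points apart, within the scatter of two such steps. Within the data shown here, all of these steps lie within the scatter, so the agreement shows only that neither change gave a readable step on either core, not that a larger step would carry over or that the changes would behave alike on other cores.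

The compounds shown leave open how a methyl group or a 4-methoxyphenyl group on the sulfonyl sulfur would read. They also leave open what an amine or a carboxylic acid would do at the aromatic carbon that carries the chloro.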